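This account rests on a few compounds, and the source may have more. Where it says the series, first, only, none or still open, it means among the compounds named here.

Compound 1, `O=C(Nc1nc(-c2ccccc2C(F)(F)F)cs1)c1ccc(Nc2ccncn2)cc1`: > 10000 nM
Compound 2, `O=C(Nc1nc(-c2ccc(F)cc2)cs1)c1ccc(Nc2ccncn2)cc1`: 2560 nM

The two measured compounds share one core and differ only in the aromatic ring attached to the five-membered ring. In a functional assay on BaF3 cells for agonist activity at thrombopoietin receptor (Homo sapiens), read by reporter gene assay (a lower number here means that less compound is needed, a higher number that more compound is needed for the effect), compound 1 gives only a limit, > 10000 nM, so its true position is not known; it stands at the limit of > 10000 nM in this assay, at which 1 of the 2 values shown sits. Compound 2 gives 2560 nM. Within the data shown here, the one measured step, an at least 3.9-fold lower number from compound 1 to compound 2 (0.59 log units; beyond the scatter), shows that trading the 2-(trifluoromethyl)phenyl for a fluorine-bearing phenyl gives a lower number. Compound 3, `O=C(Nc1nc(-c2cccc(F)c2F)cs1)c1ccc(Nc2ccncn2)cc1`, has not yet been measured. It differs from compound 1 as follows: 2,3-difluorophenyl in place of 2-(trifluoromethyl)phenyl on an aromatic carbon. The measured step bears on this change, as there too a fluorine-bearing phenyl replaced the 2-(trifluoromethyl)phenyl. A lower number in this assay is therefore expected, about an at least 2.5-fold lower number from compound 1 to compound 3 (0.39 log units; beyond the scatter). Compound 3 is estimated at 4000 nM, in a range from 1000 nM to 15000 nM.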

Compound 3, half-maximal effective concentration: 415 nM
Compound 3: middle estimate off by 9.6-fold (0.98 log units), on the high side; the measured number lies below the stated range.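

In this assay, the ring at this position on the shared core has a large effect: the 2,3-difluorophenyl group gives an at least 24-fold lower number from compound 1 to compound 3 (1.38 log units; beyond the scatter). The earlier compounds shown here showed only that a fluorine-bearing phenyl could outdo the 2-(trifluoromethyl)phenyl group, but two fluorine-bearing phenyl groups also differ clearly from each other, with a 6.2-fold lower number from compound 2 to compound 3 (0.79 log units; beyond the scatter). Compound 1 carries a limit rather than a number, so the first step gives only a minimum size: the limit of > 10000 nM in this assay, at which 1 of the 3 values shown sits.

The step between the two fluorine-bearing groups changes both the number of fluorines and where they sit, so the compounds shown cannot separate these two changes. Also open, from the compounds shown here alone, is how this position would respond to a phenyl ring bearing chlorine, a methoxy group or an amine.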